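This account rests on a few compounds, and the source may have more. Where it says the series, first, only, none or still open, it means among the compounds named here.

Compound 2 `N#CCCCn1c(Cn2c(=O)[nH]c3ccncc32)nc2ccccc21` gives 264000 nM in an ADME assay on HEp-2 cells (Homo sapiens) for cytotoxicity (on this read-out higher numbers stand for lower toxicity in this test and lower numbers for higher toxicity in this test), the highest of the two numbers that have been obtained. Compound 1 `C=C(C)n1c(=O)n(Cc2nc3ccccc3n2CCCC#N)c2cccnc21` gives 150000 nM in this assay; the gap to compound 2 lies within the scatter, so no order between the two can be drawn. Compound 3 `CC(C)(C)n1c(=O)n(Cc2nc3ccccc3n2CCCC#N)c2cnccc21` reaches only a limit in this assay, namely > 86800 nM. Going by the values given here, the single measured step that exchanges hydrogen on an aromatic nitrogen for a larger group, a step that the limit leaves unreadable from compound 2 to compound 3, is thereby left without a readable size, owing to the limit of > 86800 nM in this assay, at which 1 of the 3 values shown sits. Compound 4 `N#CCCCn1c(Cn2c(=O)n(C3CCC3)c3ccncc32)nc2ccccc21` has not yet been measured. It differs from compound 2 by cyclobutyl in place of hydrogen on an aromatic nitrogen. Among the compounds with values here, since no measured step of comparable kind reads out, no step beyond the scatter is expected in either direction in this assay. The expectation for compound 4 is 200000 nM, within the span from 70000 nM to 500000 nM. This expected outcome corresponds to a step of a 1.3-fold lower number from compound 2 to compound 4 (0.12 log units; within the scatter).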

Compound 4, half-maximal cytotoxic concentration: > 258000 nM
Compound 4: no number, only a limit (the forecaster's own chance of this, stated with the estimate: 40%); middle value at least 1.2-fold (0.11 log units) from the limit.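

Compound 4 gives only a limit in this assay, and the steps to compound 4 from compound 2 and from compound 3 cannot be read. The compounds shown leave open whether cyclobutyl in place of hydrogen on an aromatic nitrogen changes the half-maximal cytotoxic concentration at all.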